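The source may report more compounds than this note shows. Statements on the series, on what has been measured and on what is new or still open speak of the compounds shown alone.

Compound 1 `CCN(C1=NCCN1)c1c(Br)cccc1Br` is the reference point of this comparison. In a physicochemical assay for acid dissociation, compound 1 gives 11.1. Two companions have been measured alongside it: compound 2 `C/C=C/CN(C1=NCCN1)c1c(Br)cccc1Br` gives 11 in this assay, and compound 3 `C#CCN(C1=NCCN1)c1c(Br)cccc1Br` gives 10.1. Among these three numbers compound 1 stands highest; the nearest is compound 2, a step that reads a number 0.10 log units lower from compound 1 to compound 2 (within the scatter), and the furthest is compound 3, with a number 1.00 log units lower from compound 1 to compound 3 (beyond the scatter). Between the other two the step is a number 0.90 log units lower from compound 2 to compound 3 (beyond the scatter).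

Compound 4 `Brc1cccc(Br)c1N(CC1CCCCC1)C1=NCCN1` has not yet been measured. It differs from compound 1 in one place: cyclohexyl in place of methyl on a saturated chain carbon bound to a nitrogen on an aromatic ring. The measured steps that bear on this are the two leaving from compound 1. Replacing methyl with prop-1-en-1-yl left the number unchanged within the scatter, while replacing it with ethynyl lowered it by a modest amount beyond the scatter. Among the measured compounds shown here, the group that enters in compound 4 is a six-membered non-aromatic ring of carbon only, with no hydrogen-bond donors or acceptors, and it contains neither of the unsaturated pieces seen in compound 2 or compound 3, so there is no measured step pointing to a shift. The expectation for compound 4 is therefore a step of no change at the digits printed from compound 1 to compound 4 (within the scatter), within the scatter. Compound 4 is estimated at 11.1, with a range from 10.7 to 11.5.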

Compound 4, acid dissociation constant: 11.2
Beside the measured number, compound 4's estimate is 0.10 log units below it; measured number inside the range.
By their numbers in this assay, from the lowest: compound 3; then compounds 2, 1 and 4 (each within the scatter of the next).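

In this assay, six heavy atoms in a ring of carbon now stand where methyl's single carbon stood, and the step is a number 0.10 log units higher from compound 1 to compound 4 (within the scatter). Compared with the prop-1-en-1-yl group of compound 2, cyclohexyl gives a number 0.20 log units higher from compound 2 to compound 4 (within the scatter), so at this place, on a saturated chain carbon bound to a nitrogen on an aromatic ring, three quite different groups (methyl, prop-1-en-1-yl and cyclohexyl) all lie within the scatter of one another, and group size as counted in heavy atoms does not track the number across these compounds. Ethynyl now stands alone among the four, and the step away from it is the largest seen at this place: a number 1.10 log units higher from compound 3 to compound 4 (beyond the scatter).

Nothing available here accounts for why ethynyl alone departs from the other three groups. On these data alone, it remains open whether a group such as a nitrile, a phenyl ring or an amine at this place would stay with the three close compounds or shift the number as ethynyl does.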